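Cinnamamide series: difluorophenyl in place of trifluoromethylphenyl

The source may report more compounds than this note shows. Statements on the series, on what has been measured and on what is new or still open speak of the compounds shown alone.

Of the compounds shown here, three on a shared core have been measured. Compound 1 `COc1ccc(/C=C/C(=O)Nc2cc(C(=O)c3cc(OC)c(OC)c(OC)c3)ccc2OC)cc1` gives 11800 nM in a functional assay on ME-180 cells (Homo sapiens) for cytotoxicity, read by MTT assay, with a stated time of 72 h; on this read-out lower numbers stand for stronger inhibition and higher numbers for weaker inhibition. Compound 2 `C#CCOc1cccc(/C=C/C(=O)Nc2cc(C(=O)c3cc(OC)c(OC)c(OC)c3)ccc2OC)c1` gives 15300 nM in this assay, and the move between them is a 1.3-fold higher number from compound 1 to compound 2 (0.11 log units; within the scatter). Compound 3 `COc1ccc(C(=O)c2cc(OC)c(OC)c(OC)c2)cc1NC(=O)/C=C/c1ccc(C(F)(F)F)cc1` gives 800 nM in this assay, the lowest of the three numbers; its nearest neighbour is compound 1, with a 15-fold lower number from compound 1 to compound 3 (1.17 log units; beyond the scatter), and the wider gap is a 19-fold lower number from compound 2 to compound 3 (1.28 log units; beyond the scatter).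

Compound 4 `COc1ccc(C(=O)c2cc(OC)c(OC)c(OC)c2)cc1NC(=O)/C=C/c1ccc(F)c(F)c1` differs from compound 3 in one place: 3,4-difluorophenyl in place of 4-(trifluoromethyl)phenyl on a double-bonded chain carbon bound to a double-bonded chain carbon. For the measured compounds named here, no measured step exchanges one fluorinated ring for another, so the bearing steps are only those into compound 3, both large and both in the same direction. The new ring keeps fluorine on the aromatic carbon but loses the group that made the large difference, so a move back toward the numbers of compound 1 and compound 2 is expected, tempered by the remaining fluorines. The step expected here is a 3.8-fold higher number from compound 3 to compound 4 (0.57 log units; beyond the scatter). Compound 4 is estimated at 3000 nM, in a range from 700 nM to 12000 nM.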

Compound 4, half-maximal inhibitory concentration: 8900 nM
Compound 4: the middle estimate sits 3.0-fold (0.47 log units) below what was measured; measured number inside the range.
By their numbers in this assay, from the lowest: compound 3; then compounds 4, 1 and 2 (each within the scatter of the next).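

In this assay, fluorine on the ring does not by itself keep the low number of compound 3 (an 11-fold higher number from compound 3 to compound 4 (1.05 log units; beyond the scatter)), so among the four rings shown on this double-bonded chain carbon, only 4-(trifluoromethyl)phenyl stands apart. The 3,4-difluorophenyl ring does not separate from the two oxygen-bearing rings (a 1.3-fold lower number from compound 1 to compound 4 (0.12 log units; within the scatter); a 1.7-fold lower number from compound 2 to compound 4 (0.24 log units; within the scatter)), both steps lying within the scatter, which leaves compound 1, compound 2 and compound 4 as one group and compound 3 alone. Nothing measured here bears on why the two fluorinated rings differ so widely.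

The compounds shown leave open whether the low number of compound 3 goes with trifluoromethyl as such or would also appear with a nitrile, a chlorine or a trifluoromethoxy group on that phenyl ring. They also leave open how an amine or a carboxylic acid on that ring would read in this assay.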